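Triazole substituent swap on the ascorbate-derived core

A few compounds are considered here, and "the series" means these few. Any claim that something is new, unique, unknown or untested is made for them only; others in the source may bear on it.

Measured so far:
compound 1, `CC(C)(C)c1cn(C[C@H](O)[C@H]2OC(=O)C(OCc3ccccc3)=C2OCc2ccccc2)nn1` — 18300 nM
compound 2, `CC(C)(C)OC(=O)N1CCN(C(=S)SCc2cn(C[C@H](O)[C@H]3OC(=O)C(OCc4ccccc4)=C3OCc3ccccc3)nn2)CC1` — > 100000 nM

Within the data shown here, compound 1 is the only compound of the series with a numerical result in a functional assay on HeLa cells (Homo sapiens) for antiproliferative activity, read by MTT assay, with a stated time of 72 h; a lower number here means a stronger inhibitor, a higher number a weaker inhibitor. In this assay compound 1 gives 18300 nM. Compound 2 reaches only a limit of this assay, > 100000 nM, so no number is known for it (the limit of > 100000 nM in this assay, at which 1 of the 2 values shown sits). Among the measured compounds shown here, no step between two measured compounds is available, so nothing here tells how a change on the aromatic carbon of the triazole moves the read-out.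

Compound 3, `O=C1O[C@H]([C@@H](O)Cn2cc(CNS(=O)(=O)c3ccc(Cl)cc3)nn2)C(OCc2ccccc2)=C1OCc1ccccc1`, differs from compound 1 by (((4-chlorophenyl)sulfonyl)amino)methyl in place of tert-butyl on an aromatic carbon. The shared core with its two benzyl ethers and the hydroxyl-bearing linker is kept; what changes is the group carried by the five-membered aromatic ring with 3 nitrogen.

For the measured compounds named here, with no measured step to lean on, the expectation for the step from compound 1 to compound 3 in this assay is a small shift toward a weaker inhibitor, a 1.6-fold higher number from compound 1 to compound 3 (0.21 log units; within the scatter), with a real chance that only a limit is reported. Compound 3 is expected to give about 30000 nM, estimated within 8000 nM to 120000 nM.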

Compound 3, half-maximal inhibitory concentration: 13600 nM
Compound 3: the middle estimate sits 2.2-fold (0.34 log units) above what was measured; measured number inside the range.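

The aromatic carbon of the five-membered aromatic ring with 3 nitrogen now has its first readable step: in this assay, (((4-chlorophenyl)sulfonyl)amino)methyl in place of tert-butyl gives a 1.3-fold lower number from compound 1 to compound 3 (0.13 log units; within the scatter). Compound 1 and compound 3 therefore cannot be told apart in this read-out, even though the entering group brings a six-membered aromatic ring and a hydrogen-bond donor that tert-butyl lacks, so a numerical result at this position does not depend on keeping tert-butyl. Large groups at this position do not all behave alike, and compound 2 goes against any such reading, as it stays a limit of the assay and gives no number: the limit of > 100000 nM in this assay, at which 1 of the 3 values shown sits.

Among these compounds, the single step does not show which part of the entering group matters, whether the chlorine, the phenyl ring or the sulfonyl link. Also open, from the compounds shown here alone, is how a simple amine or a carboxylic acid on the same methyl would read in this assay, and whether a longer chain between the ring and the sulfonyl group would leave the read-out where it stands.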